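A few compounds are considered here, and "the series" means these few. Any claim that something is new, unique, unknown or untested is made for them only; others in the source may bear on it.

Measured compounds:
compound 1 `CCCCCCCCC#Cc1cn(C/C=C\CN2C(=O)c3ccccc3C2=O)c(=O)[nH]c1=O`: 64000 nM
compound 2 `CCCCCCCCC#Cc1cn(C/C=C/CN2C(=O)c3ccccc3C2=O)c(=O)[nH]c1=O`: 66000 nM
compound 3 `O=C1c2ccccc2C(=O)N1C/C=C/Cn1cc(C#CCCc2ccccc2)c(=O)[nH]c1=O`: 13000 nM

In a functional assay on MCF7 cells (Homo sapiens) for antiproliferative activity, read by MTT assay, with a stated time of 3 days (on this read-out lower numbers stand for stronger inhibition and higher numbers for weaker inhibition), compound 1 gives 64000 nM, the second highest of the three numbers. Compound 2 stands closest, with a 1.0-fold higher number from compound 1 to compound 2 (0.01 log units; within the scatter), which is what one expects because of the fact that compounds 1 and 2 differ only in the configuration as drawn. Among the measured compounds shown here, compound 3 stands furthest, showing a 5.1-fold lower number from compound 2 to compound 3 (0.71 log units; beyond the scatter); this is the only measured step that swaps a plain chain for an aromatic ring, and it lowered the number modestly.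

Compound 4 `CCCCc1ccc(C#Cc2cn(C/C=C\CN3C(=O)c4ccccc4C3=O)c(=O)[nH]c2=O)cc1` is not yet measured. It differs from compound 1 by 4-butylphenyl in place of octyl on a triple-bonded carbon. The change resembles the step from compound 2 to compound 3, in that an alkyl chain gives way to a ring bearing carbon, though here the ring sits directly on the triple-bonded carbon and itself carries a butyl chain, so the closeness of the analogy is uncertain.

Given that single comparable step, compound 4 is expected to show a modestly lower number than compound 1, with a 3.2-fold lower number from compound 1 to compound 4 (0.51 log units; beyond the scatter). The estimate for compound 4 in this assay is therefore 20000 nM, within a range from 6000 nM to 65000 nM.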

Compound 4, half-maximal inhibitory concentration: 43000 nM
Compound 4: middle estimate off by 2.2-fold (0.33 log units), on the low side; the range from low to high includes it.
By their numbers in this assay, from the lowest: compound 3; then compounds 4, 1 and 2 (each within the scatter of the next).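

In this assay the change at this position gives a 1.5-fold lower number from compound 1 to compound 4 (0.17 log units; within the scatter), so 4-butylphenyl can stand in place of octyl on the triple-bonded carbon with no change that can be told from the scatter. A six-membered aromatic ring in this side chain therefore does not by itself go with a lower number: the earlier change of hexyl to phenyl, on a saturated chain carbon two bonds along the chain from a triple-bonded carbon, gave a 5.1-fold lower number from compound 2 to compound 3 (0.71 log units; beyond the scatter), while here the ring sits directly on the triple-bonded carbon and carries a butyl chain. Nothing among the facts at hand explains why these two ring-bearing changes read differently.

Still open, going by these compounds, is whether a plain phenyl on this triple-bonded carbon, or a phenyl carrying an amine or a carboxylic acid in place of the butyl chain, would read like compound 4. Also open is whether drawing the double bond E rather than Z would matter with 4-butylphenyl at this position, since the only such pair shown carries octyl.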